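A few compounds are considered here, and "the series" means these few. Any claim that something is new, unique, unknown or untested is made for them only; others in the source may bear on it.

Measured compounds:
- compound 1 `N#CC1=C(N)OC(c2c[nH]c3ccccc23)=C(C#N)C1c1cccc2ccccc12`: 4.7%
- compound 2 `CN(C)c1ccc(C2C(C#N)=C(N)OC(c3c[nH]c4ccccc34)=C2C#N)cc1`: 14.4%

Both have been run in a functional assay, tested at 50 ug/mL; a lower number here means a weaker effect, a higher number a stronger effect of the compound at the concentration tested. Compound 1 gives 4.7%, the lower of the two numbers; compound 2 gives 14.4%. Among the measured compounds shown here, the only step available, a number 9.7 percentage points higher from compound 1 to compound 2 (within the scatter), is within the scatter, so the two measured compounds are not distinguished by this assay.

Compound 3 `COc1ccc(C2C(C#N)=C(N)OC(c3c[nH]c4ccccc34)=C2C#N)cc1OC` has not yet been measured. It differs from compound 1 only at the substituent on the saturated ring carbon of the shared core: 3,4-dimethoxyphenyl in place of naphthalen-1-yl on a saturated ring carbon.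

For the measured compounds named here, the one step that bears on this change is the exchange of the same aryl group at the same place, a number 9.7 percentage points higher from compound 1 to compound 2 (within the scatter), which did not move the read-out beyond the scatter. On that basis a second aryl exchange at this position is expected to give at most a small change, and no step beyond the scatter in this assay is anticipated: the expected step is a number 5.3 percentage points higher from compound 1 to compound 3 (within the scatter). For compound 3 the estimate is 10%, with a range from 0% to 25%, pending the actual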

Compound 3, a percentage reported as activity, at one concentration (the size of the read-out at that concentration, not a potency): 14.5%
Compound 3: the middle estimate sits 4.5 percentage points below what was measured; the measured number falls inside the stated range.
By their numbers in this assay, from the lowest: compounds 1, 2 and 3 (each within the scatter of the next).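

In this assay, a second aryl exchange on the saturated ring carbon, 3,4-dimethoxyphenyl in place of naphthalen-1-yl, gives a number 9.8 percentage points higher from compound 1 to compound 3 (within the scatter) and so adds a second replacement of naphthalen-1-yl at this position that stays inside the scatter. Among the compounds shown here, the exchange between the two substituted phenyl groups, 3,4-dimethoxyphenyl in place of 4-(dimethylamino)phenyl, gives a number 0.1 percentage points higher from compound 2 to compound 3 (within the scatter) and shows for the first time that these two groups are not told apart by this assay at the concentration tested. No measurement at hand offers an explanation for these readings.

Still open, going by these compounds, is whether any group on the saturated ring carbon can move this read-out beyond the scatter, for example a carboxylic acid on the phenyl ring or a short alkyl chain in place of the aryl group. Also open, on these data alone, is what an exchange elsewhere on the shared core would do, such as a simple phenyl in place of the 1H-indol-3-yl group, which all three compounds carry unchanged.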